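The source may report more compounds than this note shows. Statements on the series, on what has been measured and on what is new or still open speak of the compounds shown alone.

In a functional assay on A549 cells (Homo sapiens) for antiproliferative activity, read by MTT assay, with a stated time of 48 h (a higher number here means a weaker inhibitor, a lower number a stronger inhibitor), two compounds have been measured so far. Compound 1 (`Fc1ccc(-c2nn(-c3ccccc3)cc2-c2nc3cc(Br)ccc3[nH]2)cc1`) gives 5830 nM, and compound 2 (`Cc1ccc2[nH]c(-c3cn(-c4ccccc4)nc3-c3ccc(F)cc3)nc2c1`) gives 1440 nM, the lower of the two numbers and so the stronger inhibitor of the pair.

Compound 3 (`O=C(OCc1ccccc1)c1ccc2[nH]c(-c3cn(-c4ccccc4)nc3-c3ccc(F)cc3)nc2c1`) keeps the core of compound 2 but has benzyloxycarbonyl in place of methyl on an aromatic carbon.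

Within the data shown here, only one measured step offers any guidance, a 4.0-fold lower number from compound 1 to compound 2 (0.61 log units; beyond the scatter), where methyl replaced bromo on an aromatic carbon. That step was modest but beyond the scatter, so a single swap of this kind can shift the number in this assay. However, neither measured compound carries anything resembling benzyloxycarbonyl, so the data say little about its direction. Among the measured compounds shown here, with only two values available, a modest move toward a weaker number seems the more cautious expectation, though a result close to compound 2 would be no surprise.

The expected change is a 1.7-fold higher number from compound 2 to compound 3 (0.24 log units; within the scatter), an estimate with wide uncertainty. For compound 3, the expected value is about 2500 nM, with an estimated range from 700 nM to 9000 nM.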

Compound 3, half-maximal inhibitory concentration: 21500 nM
The estimate for compound 3 lay 8.6-fold (0.93 log units) below the measured number; measured number outside the range, above it.
By their numbers in this assay, from the lowest: compound 2; then compound 1; then compound 3.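

In this assay, this position tolerates far less than the earlier swap of bromo for methyl suggested: benzyloxycarbonyl in place of methyl gives a 15-fold higher number from compound 2 to compound 3 (1.17 log units; beyond the scatter) and so moves the number much further than a 4.0-fold lower number from compound 1 to compound 2 (0.61 log units; beyond the scatter) did. The new group also compares poorly with bromo, with a 3.7-fold higher number from compound 1 to compound 3 (0.57 log units; beyond the scatter) when it replaces bromo on the same aromatic carbon, so among the three groups shown, benzyloxycarbonyl gives the weakest inhibitor, and both of its steps lie beyond the scatter. No measurement here explains why this group, which brings a carbon-only aromatic ring and hydrogen-bond acceptors to this carbon, raises the number.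

The compounds shown leave open whether the weaker result belongs to the whole benzyloxycarbonyl group or to only one part of it, since a carboxylic acid or a methyl ester at this carbon would keep the carbonyl while losing the benzyl part. They also leave open how a group of a different kind would behave at the same carbon, such as an amine or a methoxy group.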